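This account rests on a few compounds, and the source may have more. Where it says the series, first, only, none or still open, it means among the compounds named here.

Compound 1 `COc1ccccc1-n1nc(C(=O)NCC(=O)Nc2nc3ccccc3s2)c2ccccc2c1=O`: 10000 nM
Compound 2 `CCOc1ccc(NC(=O)CSc2nc3c(c(=O)n2-c2ccccc2)SCC3)cc1`: 1000 nM
Compound 3 `O=C(CSc1nc2c(c(=O)n1-c1ccc(F)cc1)SCC2)Nc1nc2ccc(Cl)cc2s1`: 175 nM

All three were run in an assay on L cells for inhibition of Protein-serine O-palmitoleoyltransferase porcupine (Mus musculus), read by reporter gene assay, with a stated time of 24 h; on this read-out lower numbers stand for an effect already at smaller amounts and higher numbers for an effect only at larger amounts of compound. On these numbers compound 2 stands second highest of the three: compound 3 lies lower by a step beyond the scatter, and compound 1 lies higher, also beyond the scatter. Going by the values given here, no two of the measured compounds differ in only one place, so no single-point step is available as a yardstick.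

Compound 4 `CC(=O)c1ccc(NC(=O)CSc2nc3c(c(=O)n2-c2ccccc2)SCC3)cc1` is the next to be measured. Against compound 2 the change is acetyl in place of ethoxy on an aromatic carbon. Nothing measured in this assay reports on such a swap at that position; compound 3 alters the anilide end and the fluorine together, so it does not isolate the change. Among the compounds with values here, with no guiding step, the expectation is a number close to that of compound 2, with no direction favoured beyond the scatter. The step of no change at the digits printed from compound 2 to compound 4 (within the scatter) is therefore estimated to stay within the scatter. Compound 4 is expected at about 1000 nM, with a range from 300 nM to 3500 nM.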

Compound 4, half-maximal effective concentration: > 1000 nM
Compound 4: only a limit was reported; the forecaster's own chance of this, stated with the estimate: 15%; the middle value sits exactly at the limit.
By their numbers in this assay, from the lowest: compound 3; then compound 2; then compound 1.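

In this assay compound 4 gives > 1000 nM, which is a limit of the assay and not a number. Acetyl in place of ethoxy on an aromatic carbon, para to a large group, provides the first one-place step in the series: a number no lower from compound 2 to compound 4 (the limit leaves the size open). The size of this step cannot be read, so the data show no gain from acetyl at this position but cannot separate a loss from no change: the limit of > 1000 nM in this assay, at which 1 of the 4 values shown sits.

As far as these compounds go, it remains open how an amine, a carboxylic acid or a longer alkoxy chain would read on this aromatic carbon. Compound 3, at 175 nM, differs from compound 2 in more than one place, so its lower number cannot yet be assigned to any single change.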